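Swapping the amide substituent back to a dimethylmorpholine

The compounds below may be only part of what the source reports. "The series", "measured", "known", "first", "only" and "open" are said of these compounds alone.

Measured so far:
- compound 1, `CC1CN(C(=O)c2ccc(-c3ccc(NC(=O)Nc4ccc(Cl)c(C(F)(F)F)c4)cc3)cc2)CC(C)O1`, in a functional assay on MX1 cells (Homo sapiens) for inhibition, read by MTT assay, with a stated time of 120 h (a higher number here means a weaker inhibitor, a lower number a stronger inhibitor), gives > 50000 nM, a limit of the assay rather than a number
- compound 2, `CC(NC(=O)c1ccc(-c2ccc(NC(=O)Nc3cc(C(F)(F)F)ccc3Cl)cc2)cc1)c1ccccc1`, in this assay gives 17700 nM
- compound 3, `CC(NC(=O)c1ccc(-c2ccc(NC(=O)Nc3ccc(Cl)c(C(F)(F)F)c3)cc2)cc1)c1ccccc1`, in this assay gives 4630 nM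

Compound 2 holds the highest of the two numbers given; its nearest neighbour is compound 3, reached by a 3.8-fold lower number from compound 2 to compound 3 (0.58 log units; beyond the scatter), a change only in the aryl group on the urea nitrogen. The value of compound 1 in this assay is a limit, so compound 1 stands apart from these two numbers.

Compound 4, `CC1CN(C(=O)c2ccc(-c3ccc(NC(=O)Nc4cc(C(F)(F)F)ccc4Cl)cc3)cc2)CC(C)O1`, has not yet been measured in this assay. It differs from compound 2 in one place: 2,6-dimethylmorpholin-4-yl in place of (1-phenylethyl)amino on a carbonyl carbon. The same exchange, run in the opposite direction, is seen between compound 1 and compound 3, where an at least 10-fold lower number from compound 1 to compound 3 (1.03 log units; beyond the scatter): replacing the dimethylmorpholine with the phenylethylamine lowered the number by a large amount. Putting the dimethylmorpholine back on the carbonyl carbon is therefore expected to raise the number of compound 4 by a similarly large margin, and because compound 1 already sits at the limit of > 50000 nM in this assay, at which 1 of the 3 values shown sits, compound 4 may well return only a limit as well.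

Compound 4 is thus estimated at 100000 nM, with a range from 40000 nM to 300000 nM, which means an expected step of a 5.6-fold higher number from compound 2 to compound 4 (0.75 log units; beyond the scatter).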

Compound 4, half-maximal inhibitory concentration: > 50000 nM
Compound 4 ended at the assay's limit; the forecaster's own chance of this, stated with the estimate: 70%; the middle value does not contradict the limit.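

In this assay, replacing (1-phenylethyl)amino with 2,6-dimethylmorpholin-4-yl on the carbonyl carbon now also has a reading with the 2-chloro-5-(trifluoromethyl)phenyl group on the urea, giving an at least 2.8-fold higher number from compound 2 to compound 4 (0.45 log units; beyond the scatter). The weakening seen with the dimethylmorpholine is therefore not tied to one aryl group, and the change points the same way on both cores: the same change on two cores in this assay, an at least 10-fold lower number (1.03 log units; beyond the scatter) from compound 1 to compound 3 and an at least 2.8-fold lower number (0.45 log units; beyond the scatter) from compound 4 to compound 2; the limit leaves it open whether they differ. Compound 1 and compound 4 both end at a limit of the assay, so the step between them, which changes only the aryl group, cannot be read: the limit of > 50000 nM in this assay, at which 2 of the 4 values shown sit.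

The compounds shown do not separate the parts of the (1-phenylethyl)amino group, so it stays open whether the amide hydrogen, the phenyl ring or the branching methyl group accounts for the difference, which a benzylamine or an aniline on the same carbonyl carbon could help to test. On these data alone, it also stays open whether the two methyl groups of the dimethylmorpholine matter, a question that a plain morpholine or a piperidine at this place could address.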